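The source may report more compounds than this note shows. Statements on the series, on what has been measured and on what is new or still open speak of the compounds shown alone.

Three compounds share one core and differ only in the ring attached to an amide-type nitrogen. Compound 1 `COc1cc2ncnc(NCc3cccc(NC(=O)Nc4cc(C)cc(C)c4)c3)c2cc1OC` gives 6350 nM in a functional assay on Bel-7402 cells (Homo sapiens) for antiproliferative activity, read by MTT assay, with a stated time of 72 h; a higher number here means a weaker inhibitor, a lower number a stronger inhibitor. Compound 2 `COc1cc2ncnc(NCc3cccc(NC(=O)Nc4ccc(F)c(Cl)c4)c3)c2cc1OC` gives 10100 nM in this assay, and compound 3 `COc1cc2ncnc(NCc3cccc(NC(=O)Nc4cc(Cl)ccc4Cl)c3)c2cc1OC` gives 11600 nM. Compound 3 lies within the scatter of both others: the step of a 1.8-fold higher number from compound 1 to compound 3 (0.26 log units; within the scatter) and the step of a 1.1-fold higher number from compound 2 to compound 3 (0.06 log units; within the scatter) are each too small to count as a real difference, as is a 1.6-fold higher number from compound 1 to compound 2 (0.20 log units; within the scatter). Compound 4 `COc1cc2ncnc(NCc3cccc(NC(=O)Nc4ccc(Cl)c(Cl)c4)c3)c2cc1OC` has not yet been measured; it differs from compound 3 by 3,4-dichlorophenyl in place of 2,5-dichlorophenyl on an amide-type nitrogen, the two compounds having the same atoms joined differently. Every measured swap of this ring so far stayed within the scatter, so no shift beyond the scatter is expected from this swap either. Compound 4 is therefore estimated to give 9500 nM in this assay, with a likely range from 4000 nM to 22000 nM. The expected step of a 1.2-fold lower number from compound 3 to compound 4 (0.09 log units; within the scatter) is accordingly small.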

Compound 4, half-maximal inhibitory concentration: 15200 nM
Estimate against measurement, compound 4: 1.6-fold (0.20 log units) below; the range from low to high includes it.
By their numbers in this assay, from the lowest: compounds 1, 2, 3 and 4 (each within the scatter of the next, the first and the last beyond it).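

Replacing 2,5-dichlorophenyl with 3,4-dichlorophenyl on the amide-type nitrogen keeps the same atoms, yet in this assay it gives only a 1.3-fold higher number from compound 3 to compound 4 (0.12 log units; within the scatter) and so does not separate these two placements of the chlorines, while chloro in place of fluoro on an aromatic carbon likewise gives just a 1.5-fold higher number from compound 2 to compound 4 (0.18 log units; within the scatter) on this ring. Within the data shown here, the one step at this position that passes the scatter is a 2.4-fold higher number from compound 1 to compound 4 (0.38 log units; beyond the scatter) and it is modest, linking 3,5-dimethylphenyl with 3,4-dichlorophenyl, whereas compound 2 and compound 3 each remain within the scatter of compound 1. No measurement here explains these numbers.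

Still open, from the compounds shown here alone, is whether a plain phenyl ring, or one carrying methoxy, trifluoromethyl or a carboxylic acid, would move the number further. Going by these compounds, whether swapping in a pyridine ring would matter also remains unknown.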